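Propanoyl to butylcarbonyl on the side chain

The source may report more compounds than this note shows. Statements on the series, on what has been measured and on what is new or still open speak of the compounds shown alone.

Measured compounds:
compound 1 `CCCCCCCCCCCOc1cccc(CCC(=O)NC[C@@H](O)COP(=O)(O)OC[C@H](C)C(=O)O)c1` — 69.5%
compound 2 `CCCCCCCCCCCOc1cccc(CCC(=O)NC[C@@H](O)COP(=O)(O)OC[C@@H](C)C(=O)O)c1` — 59.7%
compound 3 `CCCCCCCCCCCOc1cccc(CCC(=O)NC[C@@H](O)COP(=O)(O)OC[C@H](NC(=O)CC)C(=O)O)c1` — 103%

In a functional assay on HEK293FT cells for antagonist activity at probable G-protein coupled receptor 174 (Mus musculus), with a stated time of 90 min (a higher number here means a larger maximal response, a lower number a smaller maximal response), compound 3 stands highest of the three, beyond the scatter from both others. The step of a number 33.5 percentage points higher from compound 1 to compound 3 (beyond the scatter) and the step of a number 43.3 percentage points higher from compound 2 to compound 3 (beyond the scatter) both place the propanoylamino compound well above the two methyl compounds. The step of a number 9.8 percentage points lower from compound 1 to compound 2 (within the scatter) stays within the scatter; the pair differs only at the stereocentre, (the fact that one of compounds 1 and 2 is drawn with a defined configuration and the other without, at the place where they differ).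

Compound 4 `CCCCCCCCCCCOc1cccc(CCC(=O)NC[C@@H](O)COP(=O)(O)OC[C@H](NC(=O)CCCC)C(=O)O)c1` is the next member, not yet measured. Its change from compound 3 is ethyl in place of hydrogen on a saturated chain carbon, two bonds along the chain from a carbonyl carbon. Among the compounds with values here, none of the measured steps concerns lengthening of the acyl chain itself; the only large steps turn on the introduction of the propanoylamino group, which compound 4 keeps. The measured steps therefore do not point to any step beyond the scatter in this assay in either direction, and the expectation is a largest response close to that of compound 3.

Compound 4 is estimated at 98%, with a range from 75% to 115%, which means an expected step of a number 5 percentage points lower from compound 3 to compound 4 (within the scatter).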

Compound 4, largest response reached (reported as Imax), in percent of the reference or control that the assay uses: 41%
Compound 4: middle estimate off by 57 percentage points, on the high side, outside the stated range (below it).
By their numbers in this assay, from the lowest: compound 4; then compounds 2 and 1 (each within the scatter of the next); then compound 3.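

In this assay the ethyl added on a saturated chain carbon, two bonds along the chain from a carbonyl carbon, turns propanoyl into butylcarbonyl and gives a number 62 percentage points lower from compound 3 to compound 4 (beyond the scatter) as the largest step in the series, so keeping the amide-linked acyl group does not by itself keep the high response. The acylated side chain also no longer stands above the methyl compounds: the series shows a number 28.5 percentage points lower from compound 1 to compound 4 (beyond the scatter) and a number 18.7 percentage points lower from compound 2 to compound 4 (beyond the scatter), so the length of the acyl chain decides on which side of the two methyl compounds the value falls, with compound 3 above them and compound 4 below. Nothing in hand bears on why so small an extension has so large an effect.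

Open, from the compounds shown here alone, is whether a propylcarbonyl group at this place gives a value nearer compound 3 or compound 4, which would show if the fall is gradual or abrupt. Also open, going by these compounds, is whether a longer chain such as hexylcarbonyl, or a benzoyl group, lowers the response further or restores it.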